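From Dimethylphenyl to Methoxyphenyl on a Shared Core

The compounds below may be only part of what the source reports. "The series", "measured", "known", "first", "only" and "open" are said of these compounds alone.

Of the compounds shown here, three built on the same core have been tested in an assay on HL-60 cells for inhibition of glutathione S-transferase P (Homo sapiens), read by spectrophotometry, tested at 20 uM; on this read-out lower numbers stand for less inhibition and higher numbers for more inhibition at the one concentration tested (going by the name of the read-out). Compound 1 `Cc1cc(C)cc(/C=C2\CN(CC(=O)O)c3c(C)cccc3C2=O)c1` gives 17.5%. Compound 2 `COc1cccc(/C=C2\CN(CC(=O)O)c3c(C)cccc3C2=O)c1OC` gives 8.1%, and compound 3 `CCOc1ccccc1/C=C1\CN(CC(=O)O)c2c(C)cccc2C1=O` gives 15.4%. Compound 1 has the highest of the three numbers, but its gap to compound 3 and its gap to compound 2 both lie within the usual scatter of this assay, so no order among the three can be claimed.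

Compound 4 `COc1ccc(/C=C2\CN(CC(=O)O)c3c(C)cccc3C2=O)cc1` has not yet been measured in this assay. It differs from compound 1 in one place: 4-methoxyphenyl in place of 3,5-dimethylphenyl on a double-bonded chain carbon bound to a double-bonded ring carbon. Among the measured compounds shown here, no measured pair in this set shows exactly this change, so the expectation rests only on the spread of the three known numbers, all of which sit close together.

The three measured values fall within the scatter of each other, and compound 4 is expected to land in the same region. The estimated step from compound 1 a number 5.5 percentage points lower from compound 1 to compound 4 (within the scatter) is expected to be small and not beyond the scatter. Compound 4 is therefore estimated at 12%, with a likely range from 3% to 22%.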

Compound 4, a percentage reported as inhibition, at one concentration (the size of the read-out at that concentration, not a potency): 31.5%
Beside the measured number, compound 4's estimate is 19.5 percentage points below it; measured number above the stated range.
By their numbers in this assay, from the lowest: compounds 2, 3 and 1 (each within the scatter of the next); then compound 4.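

Among the compounds shown here, replacing 3,5-dimethylphenyl with 4-methoxyphenyl on a double-bonded chain carbon bound to a double-bonded ring carbon gives, in this assay, a number 14 percentage points higher from compound 1 to compound 4 (beyond the scatter), the first step in this set that can be read beyond the scatter. The read-out at this position therefore responds to the group placed there, even though both groups have 8 heavy atoms and one six-membered aromatic ring, with the entering group adding 1 hydrogen-bond acceptor. No measurement here explains why the number rises.

This single change removes two methyl groups and adds a methoxy group, so the compounds shown cannot separate the two parts of the change. As far as these compounds go, it also remains open how a 4-aminophenyl or 4-hydroxyphenyl group would behave at this position.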